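From compound 2 to compound 4: a trifluoromethyl step

The source may report more compounds than this note shows. Statements on the series, on what has been measured and on what is new or still open speak of the compounds shown alone.

Compound 1 `O=C(CCCCC(S)CCS)NO` gives 10.6%
Compound 2 `O=C(CCCCC(S)CCS)Nc1ccccc1` gives 11.6%
Compound 3 `O=C(CCCCC(S)CCS)Nc1ccc(Cl)cc1` gives 13.4%

In a functional assay on KB cells (Homo sapiens) for inhibition, read by MTT assay, with a stated time of 24 h, tested at 1 ug/mL (a lower number here means less inhibition of growth, a higher number more inhibition of growth at the concentration tested), compound 2 gives 11.6% and stands within the scatter of compound 1 and compound 3, so no order can be read among them. Compound 4 `O=C(CCCCC(S)CCS)Nc1cccc(C(F)(F)F)c1` has not been measured. It differs from compound 2 by trifluoromethyl in place of hydrogen on an aromatic carbon with trifluoromethyl in place of hydrogen on an aromatic carbon. The closest measured change, chloro in place of hydrogen on an aromatic carbon, is a number 1.8 percentage points higher from compound 2 to compound 3 (within the scatter) and the more distant one, phenyl in place of hydroxy on an amide-type nitrogen, is a number 1 percentage points higher from compound 1 to compound 2 (within the scatter) and neither leaves the scatter. The expected change is a number 1.4 percentage points higher from compound 2 to compound 4 (within the scatter) and so no step beyond the scatter is expected. For compound 4 the estimated value is 13% with an expected range from 6% to 22% in this read-out.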

Compound 4, percent growth inhibition at one concentration: "not active" (no number reported)
No number was reported for compound 4; there is nothing to compare the estimate with.
By their numbers in this assay, from the lowest: compounds 1, 2 and 3 (each within the scatter of the next).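

For the compounds shown here, compound 4 is reported in this assay only as not active, without a number, so no step from compound 2 to compound 4 can be read. From the compounds shown here alone, whether trifluoromethyl in place of hydrogen shifts growth inhibition stays open, and no evidence here bears on this result.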